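Series notes: 4-cyanophenyl in place of 2-chlorophenyl

The source may hold more compounds than are shown below. What is called first, only, known or untested is meant among the compounds shown, and "the series" means these compounds.

Measured so far, in an in vitro functional assay on cells for agonist activity at Bombesin receptor subtype-3 (Mus musculus), read by luminescence and calcium flux; on this read-out higher numbers stand for an effect only at larger amounts of compound and lower numbers for an effect already at smaller amounts:
compound 1 `O=C(O)c1ccccc1-c1ccc(CCc2ncc(CC3CCCCC3)[nH]2)cc1` gives 7.3 nM
compound 2 `O=C(O)c1ccccc1-c1ccc(CCc2ncc(CC3CCCC3)[nH]2)cc1` gives 7.9 nM
compound 3 `O=C(O)c1ccccc1-c1ccc(CCc2ncc(Cc3ccccc3Cl)[nH]2)cc1` gives 22 nM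

Compound 3 stands at the highest number of the three in this assay; the steps of a 3.0-fold higher number from compound 1 to compound 3 (0.48 log units; beyond the scatter) and a 2.8-fold higher number from compound 2 to compound 3 (0.44 log units; beyond the scatter) are both beyond the scatter, modest in size. Compound 4 `N#Cc1ccc(Cc2cnc(CCc3ccc(-c4ccccc4C(=O)O)cc3)[nH]2)cc1` differs from compound 3 only by 4-cyanophenyl in place of 2-chlorophenyl on a saturated chain carbon bound to an aromatic carbon. Within the data shown here, no measured step exchanges one aromatic ring for another at this place; the two steps above only set the aromatic ring of compound 3 apart from the saturated rings of compound 1 and compound 2. With both rings aromatic, the expected step is none beyond the scatter, a 1.3-fold higher number from compound 3 to compound 4 (0.10 log units; within the scatter) in this assay. Compound 4 is therefore estimated at 28 nM, with a range from 9 nM to 90 nM.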

Compound 4, half-maximal effective concentration: 723 nM
Estimate against measurement, compound 4: 26-fold (1.41 log units) below; measured number above the stated range.
By their numbers in this assay, from the lowest: compounds 1 and 2 (each within the scatter of the next); then compound 3; then compound 4.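

Aromatic rings are not interchangeable on this saturated chain carbon bound to an aromatic carbon: in this assay the step of a 33-fold higher number from compound 3 to compound 4 (1.52 log units; beyond the scatter) is large for 4-cyanophenyl in place of 2-chlorophenyl. Against the saturated rings, the steps of a 92-fold higher number from compound 2 to compound 4 (1.96 log units; beyond the scatter) and a 99-fold higher number from compound 1 to compound 4 (2.00 log units; beyond the scatter) are also large, so an aromatic ring as such does not fix the level here; the two aromatic rings shown differ widely. Nothing available here accounts for this loss.

Open, as far as these compounds go, is whether the loss follows the nitrile or its place on the ring. 4-Chlorophenyl and 2-cyanophenyl would separate these two readings.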